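A few compounds are considered here, and "the series" means these few. Any claim that something is new, unique, unknown or untested is made for them only; others in the source may bear on it.

Compound 1 `CCOc1ccc(O)c(C(=O)/C=C/c2ccc(C)s2)c1` and compound 2 `CCCOc1ccc(O)c(C(=O)/C=C/c2ccc(C)s2)c1` share one core and differ by methyl in place of hydrogen on a saturated chain carbon, two bonds along the chain from an oxygen on an aromatic ring. In a functional assay on Hep 3B2 cells (Homo sapiens) for cytotoxicity, read by MTT assay (on this read-out higher numbers stand for weaker inhibition and lower numbers for stronger inhibition), compound 1 gives 90200 nM, while compound 2 gives 23200 nM, a change of a 3.9-fold lower number from compound 1 to compound 2 (0.59 log units; beyond the scatter). Compound 3 `CCOc1ccc(OC)cc1C(=O)/C=C/c1ccc(C)s1` rests on a different core; how the two cores differ is not broken down here. In this assay compound 3 gives 200 nM, the lowest of the three numbers. Compound 4 `CCCOc1ccc(OC)cc1C(=O)/C=C/c1ccc(C)s1` carries the same change against compound 3, namely (methyl in place of hydrogen on a saturated chain carbon, two bonds along the chain from an oxygen on an aromatic ring), at the same place. Compound 4 is expected to show a step of a 2.5-fold lower number from compound 3 to compound 4 (0.40 log units; beyond the scatter). That expectation rests on the earlier pair, because the same change gave a 3.9-fold lower number from compound 1 to compound 2 (0.59 log units; beyond the scatter), though a single pair cannot show how fully it carries onto another core. Compound 4 is therefore estimated at 80 nM, within a likely range from 20 nM to 300 nM.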

Compound 4, half-maximal inhibitory concentration: 7000 nM
The estimate for compound 4 lay 88-fold (1.94 log units) below the measured number, and the stated range ends below it.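

In this assay the change from ethoxy to propoxy on the core of compound 3 gives a 35-fold higher number from compound 3 to compound 4 (1.54 log units; beyond the scatter) and so runs the opposite way to the step on the core of compound 1. The effect of this change therefore did not carry from one core to the other in this series, in either direction or size: the same change on two cores in this assay, a 3.9-fold lower number (0.59 log units; beyond the scatter) from compound 1 to compound 2 and a 35-fold higher number (1.54 log units; beyond the scatter) from compound 3 to compound 4, 140-fold (2.13 log units) apart, beyond the scatter of two such steps. This does not show which difference between the two cores sets the steps apart, and a single pair on each core cannot show how either step would hold on further cores.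

The compounds shown leave open how the trend continues on each core with a longer chain such as butoxy. They also leave open whether a branched chain such as isopropoxy would follow the same course.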